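Swapping a Hexyl Chain for Benzyloxy on a Shared Core

The source may report more compounds than this note shows. Statements on the series, on what has been measured and on what is new or still open speak of the compounds shown alone.

Three compounds share one core and differ only in the chain attached to the outer aromatic ring. Going by the values given here, compound 1 `CCCCCCc1ccc(-c2c(C)[nH]c(=O)n2C2CCCCC2)cc1` carries a hexyl chain; in a functional assay on brain (Rattus norvegicus, strain Wistar) for inhibition (on this read-out lower numbers stand for stronger inhibition and higher numbers for weaker inhibition), compound 1 gives 13700 nM, the only plain number among the three. Compound 2 `CCCCCCCCCCCCc1ccc(-c2c(C)[nH]c(=O)n2C2CCCCC2)cc1` carries a longer chain, and in this assay compound 2 reaches only a limit of the assay, > 100000 nM. Compound 3 `CCCCCCCCCCCCCCCCCCc1ccc(-c2c(C)[nH]c(=O)n2C2CCCCC2)cc1` carries a still longer chain, and compound 3 likewise stops at a limit, > 100000 nM. Both sit at the limit of > 100000 nM in this assay, at which 2 of the 3 values shown sit. The step of an at least 7.2-fold higher number from compound 1 to compound 2 (0.86 log units; beyond the scatter) and the step of an at least 7.2-fold higher number from compound 1 to compound 3 (0.86 log units; beyond the scatter) both show that lengthening the chain weakens inhibition, while the step that the two limits leave unreadable from compound 2 to compound 3 cannot be read. Among the compounds with values here, compound 1 therefore stands as the only compound with a measurable number.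

Compound 4 `Cc1[nH]c(=O)n(C2CCCCC2)c1-c1ccc(OCc2ccccc2)cc1` has not yet been measured. Its change from compound 1 is benzyloxy in place of hexyl on an aromatic carbon. Within the data shown here, the measured steps concern only longer chains at this place, so they do not map directly onto a benzyloxy group of similar size; they warn only that larger groups there gave weaker inhibition. The expected step is small, a 1.1-fold higher number from compound 1 to compound 4 (0.04 log units; within the scatter), with wide uncertainty. Compound 4 is estimated at 15000 nM, within 4000 nM to 60000 nM.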

Compound 4, half-maximal inhibitory concentration: 8300 nM
Compound 4: middle estimate off by 1.8-fold (0.26 log units), on the high side; measured number inside the range.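

In this assay, the change gives a 1.7-fold lower number from compound 1 to compound 4 (0.22 log units; within the scatter), so the hexyl and benzyloxy groups cannot be told apart on this read-out. The earlier compounds shown here showed only that longer chains at this place ended at a limit of the assay, whereas compound 4 shows that a group with more heavy atoms than hexyl, and with an aromatic ring and an oxygen, can still give a plain number close to that of compound 1. Larger size alone therefore does not send a group at this place to the limit, although compound 2 and compound 3 remain limits, and the step between them cannot be read: the limit of > 100000 nM in this assay, at which 2 of the 4 values shown sit.

The compounds shown do not separate the roles of the oxygen and the ring in benzyloxy, which a hexyloxy chain or a plain phenyl group on the same aromatic carbon would begin to do. Also open, going by these compounds, is whether a shorter chain such as butyl, or an amine or a carboxylic acid at this place, would give stronger inhibition than the hexyl and benzyloxy groups.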